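This account rests on a few compounds, and the source may have more. Where it says the series, first, only, none or still open, it means among the compounds named here.

Among the compounds with values here, in a functional assay on U-87MG ATCC cells (Homo sapiens) for inhibition (a lower number here means a stronger inhibitor, a higher number a weaker inhibitor), only two compounds have been measured so far. Compound 1 `COc1cc(/C=C/C(=O)c2cccc(NC(=O)c3ccco3)c2)ccc1O` gives 6.65 ug/mL and compound 2 `COc1cc(/C=C/C(=O)c2cccc(NC(=O)C(C)C)c2)ccc1O` gives 8.31 ug/mL, so these two values lie within the scatter of each other and neither can be ranked above the other. Compound 3 `CCCC(=O)Nc1cccc(C(=O)/C=C/c2ccc(O)c(OC)c2)c1` differs from compound 2 by a single change: propyl in place of isopropyl on a carbonyl carbon. The two have the same atoms, joined differently. Within the data shown here, only one measured step bears on this change, because it falls at the same place: a 1.2-fold higher number from compound 1 to compound 2 (0.10 log units; within the scatter), with isopropyl in place of furan-2-yl on a carbonyl carbon. With so small a step on record, no shift beyond the scatter is expected in this assay here. The expected step is a 1.0-fold lower number from compound 2 to compound 3 (0.02 log units; within the scatter). For compound 3 the estimated value is 8 ug/mL, with an expected range of 4.5 ug/mL to 14 ug/mL.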

Compound 3, half-maximal inhibitory concentration: 5.56 ug/mL
Estimate against measurement, compound 3: 1.4-fold (0.16 log units) above; low and high end bracket the measured number.
By their numbers in this assay, from the lowest: compounds 3, 1 and 2 (each within the scatter of the next).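

In this assay, the change from isopropyl to propyl on the carbonyl carbon rearranges the same atoms and gives a 1.5-fold lower number from compound 2 to compound 3 (0.17 log units; within the scatter), so branching of this chain has no readable effect here. The change from furan-2-yl to propyl gives a 1.2-fold lower number from compound 1 to compound 3 (0.08 log units; within the scatter), so a ring and an open chain at this place also cannot be told apart, and all three groups now read alike within the scatter. No measurement here offers an explanation for this flat picture.

The compounds shown leave open whether any group at this place can move the number beyond the scatter, since all three groups are carbon-based and carry similar numbers. An amine, a carboxylic acid or a much longer chain on this carbonyl carbon would test that.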